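A few compounds are considered here, and "the series" means these few. Any claim that something is new, unique, unknown or untested is made for them only; others in the source may bear on it.

Measured compounds in a physicochemical assay for lipophilicity; a higher number here means a more lipophilic compound, a lower number a more polar compound:
- compound 1, `CCCCOC(=O)c1ccc(S(N)(=O)=O)cc1`, gives 2.34
- compound 2, `CNC(=O)c1ccc(S(N)(=O)=O)cc1`, gives -0.31
- compound 3, `CCCNC(=O)c1ccc(S(N)(=O)=O)cc1`, gives 0.51

Compound 1 stands highest of the three in this assay; compound 3 is nearest to it, compound 2 furthest, both lower by steps beyond the scatter.

The unmeasured compound 4, `CCCCCNC(=O)c1ccc(S(N)(=O)=O)cc1`, differs from compound 1 as follows: pentylamino in place of butoxy on a carbonyl carbon

Within the data shown here, two measured steps bear on this. Replacing butoxy by an amino chain on the same carbonyl carbon was seen in a number 2.65 log units lower from compound 1 to compound 2 (beyond the scatter) and in a number 1.83 log units lower from compound 1 to compound 3 (beyond the scatter), both large and downward. Lengthening the chain on the amide-type nitrogen was seen in a number 0.82 log units higher from compound 2 to compound 3 (beyond the scatter), a modest rise. Pentylamino carries two more chain carbons than propylamino, so a step of about the size of that lengthening is expected on top of the value of compound 3, leaving a large downward step in this assay overall, estimated as a number 1.01 log units lower from compound 1 to compound 4 (beyond the scatter).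

The value for compound 4 in this assay is therefore estimated at 1.33, expected between 0.9 and 1.8.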

Compound 4, partition coefficient: 1.54
Compound 4: middle estimate off by 0.21 log units, on the low side; low and high end bracket the measured number.
By their numbers in this assay, from the lowest: compound 2; then compound 3; then compound 4; then compound 1.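

On this carbonyl carbon, pentylamino in place of butoxy still lowers the number in this assay, but the drop shrinks to a number 0.80 log units lower from compound 1 to compound 4 (beyond the scatter), so an amide chain of this length recovers much of the ground lost by compound 2 and compound 3 without reaching compound 1. Along the amide chain the number rises at each lengthening, first a number 0.82 log units higher from compound 2 to compound 3 (beyond the scatter) and then a number 1.03 log units higher from compound 3 to compound 4 (beyond the scatter), and the whole change of butyl in place of hydrogen amounts to a number 1.85 log units higher from compound 2 to compound 4 (beyond the scatter), with no levelling yet across these three compounds. Nothing on hand gives a cause for these steps.

From the compounds shown here alone, whether the rise continues with a longer chain such as octylamino remains open. Also open, going by these compounds, are how butylamino compares directly with butoxy, and what a branched chain or a terminal carboxylic acid would do at this place.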